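Carbamate side-chain series: methoxy for hydrogen, one step

This account rests on a few compounds, and the source may have more. Where it says the series, first, only, none or still open, it means among the compounds named here.

Measured so far in a functional assay on L1210 cells (Mus musculus), with a stated time of 1 days; a lower number here means a less potent compound, a higher number a more potent compound, by a factor of ten per unit of this negative logarithm:
compound 1 `CCC1=C(N2CC2)C(=O)C(CCOC(N)=O)=C(N2CC2)C1=O`: 5.98
compound 2 `CCCC1=C(N2CC2)C(=O)C(CCOC(N)=O)=C(N2CC2)C1=O`: 4.9
compound 3 `COC(CO)C1=C(N2CC2)C(=O)C(C)=C(N2CC2)C1=O`: 6.05

Compound 1 stands second highest of the three numbers. Its nearest neighbour is compound 3, whose value sits within the scatter of that of compound 1, so no order between the two can be read. Compound 2 lies furthest off: the step of a number 1.08 log units lower from compound 1 to compound 2 (beyond the scatter) is large and beyond the scatter, and it arises from a methyl in place of hydrogen on a saturated chain carbon, two bonds along the chain from a double-bonded ring carbon.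

The unmeasured compound 4 `CCC1=C(N2CC2)C(=O)C(C(COC(N)=O)OC)=C(N2CC2)C1=O` differs from compound 1 by methoxy in place of hydrogen on a saturated chain carbon bound to a double-bonded ring carbon and a saturated chain carbon. Within the data shown here, only one measured step bears on it at all, the step from compound 1 to compound 2, and that step is at another place on another chain, so its bearing is indirect. Compound 3 carries a methoxy on the same kind of chain carbon as compound 4 does, yet compound 3 differs from compound 1 in more than one place, so its value beside that of compound 1 can only be noted: the two values lie within the scatter.

With a large drop seen for chain extension elsewhere and no drop visible where a methoxy is present, a small step downward or none beyond the scatter is expected for compound 4, estimated as a number 0.18 log units lower from compound 1 to compound 4 (within the scatter). Compound 4 is therefore expected at about 5.8, with a range of 5 to 6.5.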

Compound 4, logarithm of the reciprocal of the active concentration, log(1/C): 5.62
Beside the measured number, compound 4's estimate is 0.18 log units above it; low and high end bracket the measured number.
By their numbers in this assay, from the lowest: compound 2; then compound 4; then compounds 1 and 3 (each within the scatter of the next).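

In this assay, methoxy in place of hydrogen on a saturated chain carbon bound to a double-bonded ring carbon and a saturated chain carbon gives a number 0.36 log units lower from compound 1 to compound 4 (beyond the scatter) as a modest step beyond the scatter, so this carbon of the carbamate side chain accepts the methoxy at a small but readable cost. Among these compounds, this is the first reading of a change at this place: the earlier single-place step, a number 1.08 log units lower from compound 1 to compound 2 (beyond the scatter) on the other chain, concerned a different carbon, and compound 3 carries a methoxy on the same kind of carbon but differs from compound 1 in more than one place. No measurement to hand accounts for the new step.

On these data alone, whether a hydroxyl, an amine or a longer chain such as ethoxy on this carbon would leave the number higher or lower than the methoxy does stays open. Also open, as far as these compounds go, is whether the same methoxy would give a step of similar size on the core of compound 2, which carries the propyl chain.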